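A few compounds are considered here, and "the series" means these few. Any claim that something is new, unique, unknown or untested is made for them only; others in the source may bear on it.

Measured so far: compound 1 `CCC(CC)(c1nnc[nH]1)c1ccc(-c2ccc3cccc(F)c3c2)[nH]c1=O` with 0.925 h; compound 2 `CC(C)C(Nc1nccs1)c1ccc(-c2ccc3cccc(F)c3c2)[nH]c1=O` with 0.07 h.

In an ADME assay on microsomes from liver (Rattus norvegicus) for metabolic stability (on this read-out lower numbers stand for a shorter-lived compound and higher numbers for a longer-lived compound), compound 2 stands lowest of the two numbers; its nearest neighbour, compound 1, sits higher by a gap that lies beyond the usual scatter. Compound 3 `CC(C)C(/C=C1\CCNC1=O)c1ccc(-c2ccc3cccc(F)c3c2)[nH]c1=O` has not yet been measured. Its difference from compound 2: a group of 7 heavy atoms (5 carbon, 1 nitrogen, 1 oxygen; one five-membered non-aromatic ring with 1 hetero atom) in place of a group of 6 heavy atoms (3 carbon, 2 nitrogen, 1 sulfur; one five-membered aromatic ring with 2 hetero atoms), on a saturated chain carbon bound to an aromatic carbon and a saturated chain carbon. Among the measured compounds shown here, no measured pair covers such a change, so the direction rests on judgement alone. The step is expected to be a 2.9-fold higher number from compound 2 to compound 3 (0.46 log units; beyond the scatter), upward but modest. Compound 3 is expected to give about 0.2 h, within 0.05 h to 0.8 h.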

Compound 3, half-life: 0.345 h
Estimate against measurement, compound 3: 1.7-fold (0.24 log units) below, and the stated range covers the measured number.
By their numbers in this assay, from the lowest: compound 2; then compound 3; then compound 1.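

At the saturated chain carbon bound to an aromatic carbon and a saturated chain carbon, putting the group with the five-membered non-aromatic ring in place of (1,3-thiazol-2-yl)amino gives, in this assay, a 4.9-fold higher number from compound 2 to compound 3 (0.69 log units; beyond the scatter). This single step shows that the group at this position can shift the half-life while the rest of the structure stays the same. Nothing available bears on what underlies the step.

The step alone cannot separate the departure of (1,3-thiazol-2-yl)amino from the arrival of the new group. As far as these compounds go, how a plain amine or a carboxylic acid at this carbon would compare remains open.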